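The compounds below may be only part of what the source reports. "The series", "measured", "known", "first", "only" and "open" are said of these compounds alone.

Series notes, hydrazone aryl end. In an ADME assay on cells (Splenocyte, Mus musculus, strain BALB/c) for cytotoxicity, read by thymidine incorporation, with a stated time of 24 h (on this read-out lower numbers stand for stronger inhibition and higher numbers for weaker inhibition), compound 1 `COc1cc(/C=N/NC(=O)CCN2CCN(c3ccnc4cc(Cl)ccc34)CC2)ccc1OC(C)=O` gives 15800 nM. Compound 2 `CN(C)c1ccc(/C=N/NC(=O)CCN2CCN(c3ccnc4cc(Cl)ccc34)CC2)cc1` reaches only the limit of the assay, > 100000 nM (the limit of > 100000 nM in this assay, at which 1 of the 3 values shown sits). For the measured compounds named here, compound 3 `CC(C)Oc1ccc(/C=N/NC(=O)CCN2CCN(c3ccnc4cc(Cl)ccc34)CC2)cc1` gives 3600 nM, the lowest of the two numbers so far; the steps into it are a 4.4-fold lower number from compound 1 to compound 3 (0.64 log units; beyond the scatter) and an at least 27-fold lower number from compound 2 to compound 3 (1.44 log units; beyond the scatter), and the remaining measured step is an at least 6.3-fold higher number from compound 1 to compound 2 (0.80 log units; beyond the scatter). Compound 4 `O=C(CCN1CCN(c2ccnc3cc(Cl)ccc23)CC1)N/N=C/c1cccc(Cl)c1` is not yet measured; it differs from compound 3 as 3-chlorophenyl in place of 4-isopropoxyphenyl on a carbon with a double bond to nitrogen. Going by the values given here, no measured step places a halogen on this ring, so the three aryl steps only mark out how far swaps here have moved the numbers. Compound 4 is expected to give 8000 nM (range 2500 nM to 30000 nM). The step of a 2.2-fold higher number from compound 3 to compound 4 (0.35 log units; beyond the scatter) is expected to be a modest rise, compound 3 at 3600 nM being the lowest number seen.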

Compound 4, half-maximal inhibitory concentration: > 100000 nM
Compound 4: a limit, no number; the forecaster's own chance of this, stated with the estimate: 10%; middle value at least 12-fold (1.09 log units) away from the limit.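

Compound 4 is a limit, not a number, and is the second compound at that limit: the limit of > 100000 nM in this assay, at which 2 of the 4 values shown sit. On a carbon with a double bond to nitrogen, the first halogen-bearing ring gives an at least 27-fold higher number from compound 3 to compound 4 (1.44 log units; beyond the scatter), and against the other oxygen-bearing ring gives an at least 6.3-fold higher number from compound 1 to compound 4 (0.80 log units; beyond the scatter), so among the compounds shown only the two oxygen-bearing rings, in compound 1 and compound 3, give readable numbers. The step between compound 2 and compound 4 cannot be read.

On these data alone, whether 4-chlorophenyl or unsubstituted phenyl would give a readable number remains open. So does whether the chlorine or its ring position drives this step.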